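This account rests on a few compounds, and the source may have more. Where it says the series, first, only, none or still open, it means among the compounds named here.

Measured so far in a functional assay on V79 cells (Cricetulus griseus) for cytotoxicity, read by colony formation; a higher number here means a weaker inhibitor, a lower number a stronger inhibitor:
- compound 1 `NC1CCN(c2c(F)cc3c(=O)c(C(=O)O)cn(C4CC4)c3c2C(F)(F)F)C1`: 300 ug/mL; 300 ug/mL; 300 ug/mL (3 entries)
- compound 2 `COc1c(N2CCC(C)(CN)C2)c(F)cc2c(=O)c(C(=O)O)cn(C3CC3)c12`: 38 ug/mL

For the measured compounds named here, compound 2 gives 38 ug/mL, the only number it has in this assay, and one further entry for it yields no single number. Going by the values given here, that value is lower than the one for compound 1 at 300 ug/mL; 300 ug/mL; 300 ug/mL (3 entries), but these two compounds differ in more than one place, so the gap cannot be tied to any single change.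

The next compound is compound 3 `CC1(CN)CCN(c2c(F)cc3c(=O)c(C(=O)O)cn(C4CC4)c3c2C(F)(F)F)C1`, which keeps the 3-(aminomethyl)-3-methylpyrrolidin-1-yl group of compound 2 and has trifluoromethyl in place of methoxy on an aromatic carbon. Among the compounds with values here, no measured pair isolates this swap, so any expectation is rough. Within the data shown here, the only guide is that compound 1, which also carries trifluoromethyl, sits high at 300 ug/mL; 300 ug/mL; 300 ug/mL (3 entries), although it lacks that pyrrolidine group. A moderate upward move is therefore expected, with the estimated step being a 2.4-fold higher number from compound 2 to compound 3 (0.37 log units; beyond the scatter). For compound 3 the estimated value is 90 ug/mL, with an expected range from 30 ug/mL to 250 ug/mL.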

Compound 3, half-maximal inhibitory concentration: 110 ug/mL
Compound 3: middle estimate off by 1.2-fold (0.09 log units), on the low side; low and high end bracket the measured number.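

For the compounds shown here, with the 3-(aminomethyl)-3-methylpyrrolidin-1-yl group held fixed, this pair gives the first clean reading of a change at this aromatic carbon: in this assay, putting trifluoromethyl in place of methoxy gives a 2.9-fold higher number from compound 2 to compound 3 (0.46 log units; beyond the scatter) with nothing else in the structure altered. A higher number here marks a weaker inhibitor, so this position is one where the choice between these two groups shows in the read-out, and compound 3 takes more material than compound 2 to reach the same half-maximal effect on colony formation. No measurement offered here explains why the number moves, so the step stands as an observation only.

On these data alone, this is a single pair, so it remains open whether the same swap would give a similar step with a different amine-bearing ring on the shared core. As far as these compounds go, it also remains open where a chloro group, a plain methyl group or a longer ethoxy chain on this same aromatic carbon would fall relative to methoxy and trifluoromethyl.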